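A few compounds are considered here, and "the series" means these few. Any claim that something is new, unique, unknown or untested is made for them only; others in the source may bear on it.

For the measured compounds named here, the three compounds measured so far share a core built around a double-bonded chain that carries an aryl ketone and a sulfur-linked aryl group. In a functional assay on DU-145 cells (Homo sapiens) for inhibition, read by trypan blue exclusion, with a stated time of 96 h (a lower number here means a stronger inhibitor of growth, a higher number a weaker inhibitor of growth), compound 1 `COc1ccc(/C=C(/Sc2ccc(Br)cc2)C(=O)c2ccc(Cl)cc2)cc1` gives 50000 nM. Compound 2 `Cc1ccc(S/C(=C/c2ccc(Cl)c(Cl)c2)C(=O)c2ccc(Br)cc2)cc1` gives 50000 nM in this assay, level with compound 1 at the digits shown, and these two together are the highest numbers of the three. Compound 3 `Cc1ccc(S(=O)(=O)/C(=C/c2c[nH]c3ccc(Cl)cc23)C(=O)c2ccc(Br)cc2)cc1` gives 10000 nM in this assay, a lower number than that of compound 2 and the only gap among the three that goes beyond the scatter.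

Compound 4 `COc1ccc(/C=C(/Sc2ccc(C)cc2)C(=O)c2ccc(Br)cc2)cc1` has not yet been measured. It differs from compound 2 in one place: 4-methoxyphenyl in place of 3,4-dichlorophenyl on a double-bonded chain carbon bound to a double-bonded chain carbon. Going by the values given here, no measured pair shows this exchange on its own, so the size of the step has to be judged from the numbers at hand. Compound 1 already carries the same 4-methoxyphenyl group and stands at 50000 nM, no different from compound 2 at the digits shown, so nothing in the data points to a shift in either direction. Compound 4 is therefore expected to give about 50000 nM in this assay, within a range of 20000 nM to 100000 nM. The step that this estimate means, no change at the digits printed from compound 2 to compound 4 (within the scatter), is expected to lie within the scatter.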

Compound 4, concentration for 50% growth inhibition: 50000 nM
Beside the measured number, compound 4's estimate shows no gap at the digits printed, within the range that was stated.
By their numbers in this assay, from the lowest: compound 3; then compounds 1, 2 and 4 (each within the scatter of the next).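

In this assay, for the compounds shown here, the exchange of 3,4-dichlorophenyl for 4-methoxyphenyl on a double-bonded chain carbon bound to a double-bonded chain carbon gives no change at the digits printed from compound 2 to compound 4 (within the scatter) and is the first step in this set that isolates a single place. The two groups have the same count of 8 heavy atoms and the same six-membered aromatic ring of carbon only, but 2 chlorine give way to 1 oxygen and 1 hydrogen-bond acceptor enters, and this exchange leaves the number unmoved at the digits printed. Nothing measured here bears on why the number stays level.

Going by these compounds, it remains open whether a phenyl ring carrying an amine or a carboxylic acid at this place would shift the number, since the two aryl groups compared here cover only a narrow choice. On these data alone, compound 3 differs from compound 2 in more than one place, so its lower number cannot be tied to any single change, and whether this exchange would also stay level on the core of compound 3 is unknown.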